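This account rests on a few compounds, and the source may have more. Where it says the series, first, only, none or still open, it means among the compounds named here.

Compound 1 `COc1ccc(-c2nc(C)c(C(=O)CSc3nc(N)c(C#N)c(-c4ccc(Cl)cc4)n3)s2)cc1` in a functional assay on U-87MG ATCC cells for antiproliferative activity against U-87 MG (Homo sapiens), read by MTT assay, with a stated time of 48 h, tested at 5 uM (a higher number here means a weaker effect of the compound at the concentration tested, a lower number a stronger effect), gives 51.4%. Compound 3 `COc1ccc(-c2nc(C)c(C(=O)CSc3nc(-c4ccc(OC)cc4)c(C#N)c(=O)[nH]3)s2)cc1` in this assay gives 97%, and compound 2 `COc1ccc(-c2nc(SCC(=O)c3sc(-c4ccccc4)nc3C)[nH]c(=O)c2C#N)cc1` in this assay gives 97.3%. The difference between the cores of compound 1 and compound 3 is not broken down here; compound 1 stands lowest of the three. From compound 3 to compound 2 a single change is made: hydrogen in place of methoxy on an aromatic carbon That step is a number 0.3 percentage points higher from compound 3 to compound 2 (within the scatter). Compound 4 `Cc1nc(-c2ccccc2)sc1C(=O)CSc1nc(N)c(C#N)c(-c2ccc(Cl)cc2)n1` is not yet measured in this assay; it differs from compound 1 by the same change: hydrogen in place of methoxy on an aromatic carbon Because the step of a number 0.3 percentage points higher from compound 3 to compound 2 (within the scatter) lay within the scatter, a similarly small step is expected here, a number 3.6 percentage points higher from compound 1 to compound 4 (within the scatter), although the cores of the two pairs differ. Compound 4 is therefore expected to give 55% in this assay, most likely between 40% and 75%.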

Compound 4, a percentage reported as activity, at one concentration (the size of the read-out at that concentration, not a potency): 62.9%
For compound 4 the middle estimate is 7.9 percentage points below the measured one; measured number inside the range.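

In this assay, replacing 4-methoxyphenyl with phenyl gives a number 11.5 percentage points higher from compound 1 to compound 4 (beyond the scatter). Set beside the earlier step, the new one does not separate the two cores: the same change on two cores in this assay, a number 0.3 percentage points higher (within the scatter) from compound 3 to compound 2 and a number 11.5 percentage points higher (beyond the scatter) from compound 1 to compound 4, 11.2 percentage points apart, within the scatter of two such steps. The change may therefore carry from one core to the other, but two pairs do not establish that it does, nor that the core alters it, and they give no reason for either step.

The compounds shown leave open whether another group at the same place on the ring, such as fluorine, a hydroxyl or an amine, would give a similar step. They also leave open whether the same change would read alike on any further core.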